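The source may hold more compounds than are shown below. What is called first, only, known or untested is meant among the compounds shown, and "the series" means these compounds.

Of the compounds shown here, three built on a shared core have been measured in a functional assay on PC-3 cells (Homo sapiens) for cytotoxicity, read by MTT assay, with a stated time of 72 h; on this read-out lower numbers stand for stronger inhibition of growth and higher numbers for weaker inhibition of growth. Compound 1 `C[Se]/C(=N\C(=O)c1cc2ccccc2s1)NC(=O)c1cc2ccccc2s1` gives 37200 nM in this assay. Compound 2 `CS/C(=N\C(=O)c1ccno1)NC(=O)c1ccno1` gives 99200 nM in this assay. Compound 3 `C[Se]/C(=N\C(=O)c1ccco1)NC(=O)c1ccco1` gives 360 nM in this assay, the lowest of the three numbers; compound 1 stands above it by a margin beyond the scatter, and compound 2 stands further above it still, also beyond the scatter.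

Compound 4 `CS/C(=N\C(=O)c1ccco1)NC(=O)c1ccco1` has not been measured. It differs from compound 3 by a group of 2 heavy atoms (1 carbon, 1 sulfur; no ring) in place of a group of 2 heavy atoms (1 carbon, 1 selenium; no ring), on a carbon with a double bond to nitrogen. Within the data shown here, no measured pair isolates this exchange: compound 1 and compound 2 differ from each other both in the group on that carbon and in the rings attached to the amide-type nitrogens, so their two values show only that each lies far above compound 3 in this assay. Among the measured compounds shown here, the sole compound carrying the methylsulfanyl group, compound 2, holds the highest number of the set, while the two selenium-bearing compounds span the whole range. On this thin basis a step toward weaker growth inhibition in this assay is expected, of a size clearly beyond the scatter, as a 14-fold higher number from compound 3 to compound 4 (1.14 log units; beyond the scatter). Compound 4 is therefore estimated at 5000 nM in this assay, within a range from 800 nM to 40000 nM.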

Compound 4, concentration for 50% growth inhibition: 56200 nM
Compound 4: the middle estimate sits 11-fold (1.05 log units) below what was measured; the measured number lies above the stated range.
By their numbers in this assay, from the lowest: compound 3; then compounds 1, 4 and 2 (each within the scatter of the next, the first and the last beyond it).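

With the rest of the structure unchanged, replacing the selenium-bearing group with methylsulfanyl on a carbon with a double bond to nitrogen gives, in this assay, a 160-fold higher number from compound 3 to compound 4 (2.19 log units; beyond the scatter), a large step well beyond the scatter. Among these compounds, this is the first pair in the set to isolate this exchange, and it shows that the change at this one place is enough on its own to separate the low number of compound 3 from the far higher number of compound 4. Nothing available here explains why this single exchange has so large an effect on growth inhibition.

The compounds shown compare the two groups on only one set of rings, so whether a step of similar size would appear with the rings of compound 1 or compound 2 remains open. On these data alone, it also remains open how this assay would respond to other groups on that carbon, such as an amine or a longer chain like ethylsulfanyl.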